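The compounds below may be only part of what the source reports. "The series", "measured", "known", "first", "only" and "open" are said of these compounds alone.

Working notes on a small series built on a shared core. Compound 1 `CCn1nc(Cc2ccc(SC)cc2)c2ccccc2c1=O` carries a methyl on the saturated chain carbon bound to the aromatic nitrogen. In a functional assay on aorta with Alpha-1D adrenergic receptor (Rattus norvegicus) as the target (a lower number here means that less compound is needed, a higher number that more compound is needed for the effect), compound 1 gives > 100000 nM, which is a limit of the assay and not a number. Among the compounds with values here, compound 2 `COc1ccc(Cc2nn(C(C)(C)C)c(=O)c3ccccc23)cc1OC` is the only other measured member; in this assay compound 2 gives 10000 nM. Within the data shown here, of the two values in hand, compound 1 sits on the limit (the limit of > 100000 nM in this assay, at which 1 of the 2 values shown sits), at the end where more compound is needed, and no step between measured compounds is available to calibrate a change at the chain.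

Compound 3 `C=CCn1nc(Cc2ccc(SC)cc2)c2ccccc2c1=O` is the next member to be measured. It differs from compound 1 by vinyl in place of methyl on a saturated chain carbon bound to an aromatic nitrogen; read one bond further out, ethyl becomes allyl. Among the measured compounds shown here, no measured pair shows this change, and the rest of the molecule is untouched. The step of a number no higher from compound 1 to compound 3 (the limit leaves the size open) is expected to stay within the scatter, in no particular direction. For compound 3 the expected value in this assay is 100000 nM, with a range from 30000 nM to 300000 nM, and a limit rather than a number is the likelier outcome.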

Compound 3, half-maximal effective concentration: > 100000 nM
Compound 3: no number, only a limit; the forecaster's own chance of this, stated with the estimate: 70%; the middle value sits exactly at the limit.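

In this assay compound 3 gives > 100000 nM, which is a limit of the assay and not a number. Compound 1 also stands on a limit, so no step can be read between compound 1 and compound 3: the limit of > 100000 nM in this assay, at which 2 of the 3 values shown sit.

Going by these compounds, whether vinyl in place of methyl on a saturated chain carbon bound to an aromatic nitrogen shifts the value in this assay remains open.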